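Swapping the Fluoromethoxyphenyl End for a Phenol

The compounds below may be only part of what the source reports. "The series", "measured", "known", "first", "only" and "open" are said of these compounds alone.

Compound 1 `COc1ccc(C#Cc2ccc(C(=O)N3CCC[C@@H](CO)C3)cc2)c(F)c1F`: in a functional assay on TREX cells for negative allosteric modulation of metabotropic glutamate receptor 3 (Rattus norvegicus), read by calcium flux, with a stated time of 2.5 min (a lower number here means a stronger inhibitor, a higher number a weaker inhibitor), compound 1 gives > 10000 nM, a limit of the assay.
Compound 2 `COc1ccc(C#Cc2ccc(C(=O)N3CCC[C@@H](O)C3)c(F)c2)cc1`: in this assay compound 2 gives 450 nM; 593 nM; 603 nM (3 entries).
Compound 3 `COc1ccc(C#Cc2ccc(C(=O)N3CCC[C@@H](CO)C3)cc2)cc1F`: in this assay compound 3 gives > 10000 nM, again a limit of the assay.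

Compound 3 therefore stands only at a limit, and no single number is known for it. Among the compounds with values here, the one measured step that touches it, a step that the two limits leave unreadable from compound 1 to compound 3, cannot be read, since both ends sit at the limit of > 10000 nM in this assay, at which 2 of the 3 values shown sit. Within the data shown here, compound 2 shows that inhibition can be measured, as the several entries of compound 2 in this assay, 450 nM; 593 nM; 603 nM (3 entries) records, but compound 2 differs from compound 3 in more than one place, so its values give no step. Compound 4 `O=C(c1ccc(C#Cc2ccc(O)cc2)cc1)N1CCC[C@@H](CO)C1` is the next compound; its change from compound 3 is 4-hydroxyphenyl in place of 3-fluoro-4-methoxyphenyl on a triple-bonded carbon. Among the measured compounds shown here, no measured step bears directly on this change. With compound 3 at a limit, compound 4 is expected to stay near that limit too, the step that the limit leaves unreadable from compound 3 to compound 4 being an expectation rather than a measurement. The estimate for compound 4 is 15000 nM, with a range from 4000 nM to 50000 nM.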

Compound 4, half-maximal inhibitory concentration: > 10000 nM
Compound 4 ended at the assay's limit; the forecaster's own chance of this, stated with the estimate: 70%; the middle value is on the limit's open side.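

In this assay compound 4 gives > 10000 nM, a limit of the assay and not a number. Compound 3 also stands at a limit, so the step between compound 3 and compound 4 cannot be read. The compounds shown leave open whether 4-hydroxyphenyl in place of 3-fluoro-4-methoxyphenyl changes inhibition at all.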